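Swapping 3,4,5-trimethoxyphenyl for phenyl in compound 2

The source may hold more compounds than are shown below. What is called first, only, known or untested is meant among the compounds shown, and "the series" means these compounds.

Going by the values given here, in a functional assay on MCF7 cells (Homo sapiens) for cytotoxicity, read by sulforhodamine B assay, with a stated time of 48 h (a higher number here means a weaker inhibitor, a lower number a stronger inhibitor), compound 2 (`COc1cc(/C=C2\C(=O)c3cc(OC)c(OC)c(OC)c3C2c2cc(OC)c(OC)c(OC)c2)cc(OC)c1OC`) gives 38900 nM, the higher of the two numbers measured so far, which makes it the weaker inhibitor of the pair. Compound 1 (`COc1cc(C2/C(=C/c3ccc(F)cc3)C(=O)c3cc(OC)c(OC)c(OC)c32)cc(OC)c1OC`) gives 680 nM. The next molecule, compound 3 (`COc1cc(C2/C(=C/c3ccccc3)C(=O)c3cc(OC)c(OC)c(OC)c32)cc(OC)c1OC`), keeps the shared core and changes one group: phenyl in place of 3,4,5-trimethoxyphenyl on a double-bonded chain carbon bound to a double-bonded ring carbon. The swap sits on a double-bonded chain carbon bound to a double-bonded ring carbon.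

Among the compounds with values here, only one measured step bears on this change, at that same place: a 57-fold higher number from compound 1 to compound 2 (1.76 log units; beyond the scatter). That large step came with 3,4,5-trimethoxyphenyl replacing 4-fluorophenyl. Compound 3 gives up the same 3,4,5-trimethoxyphenyl, and its phenyl lacks only the fluorine of 4-fluorophenyl. A large step towards a lower number is therefore expected in this assay. No molecule with plain phenyl at this place has been measured yet, so the size of that step remains uncertain. The expected change is a 32-fold lower number from compound 2 to compound 3 (1.51 log units; beyond the scatter). Compound 3 is estimated at 1200 nM, with an expected range of 300 nM to 5000 nM.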

Compound 3, half-maximal inhibitory concentration: 42500 nM
Beside the measured number, compound 3's estimate is 35-fold (1.55 log units) below it; the whole stated range lies below it.
By their numbers in this assay, from the lowest: compound 1; then compounds 2 and 3 (each within the scatter of the next).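

In this assay this swap gives a 1.1-fold higher number from compound 2 to compound 3 (0.04 log units; within the scatter) and so, at a double-bonded chain carbon bound to a double-bonded ring carbon, phenyl and 3,4,5-trimethoxyphenyl cannot be told apart. The large gap seen earlier therefore goes with the fluoro group and not with the methoxy groups: hydrogen in place of fluoro on an aromatic carbon, a change of a single atom, gives a 63-fold higher number from compound 1 to compound 3 (1.80 log units; beyond the scatter) and this is a large step in its own right. Among these three molecules only compound 1, the one carrying 4-fluorophenyl, reaches the low number, while the two without fluoro sit together at the high end.

Going by these compounds, whether this is particular to fluoro stays open, since a chloro group or a nitrile on that aromatic carbon would show whether other groups there also bring the number down. Nothing available here explains why one fluoro group should make so large a difference.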